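The compounds below may be only part of what the source reports. "The series", "measured", "known", "first", "only" and "open" are said of these compounds alone.

Measured so far in a functional assay on BT-549 cells (Homo sapiens) for inhibition, read by sulforhodamine B assay, with a stated time of 48 h, tested at 10 uM; on this read-out lower numbers stand for less inhibition and higher numbers for more inhibition at the one concentration tested (going by the name of the read-out):
Compound 1, `Brc1cn2ccnc2c(-c2ccc3ncn(C4CCCCC4)c3c2)n1`: 5.16%
Compound 2, `CC(=O)c1ccc(-c2cn3ccnc3c(-c3ccc4ncn(C5CCCCC5)c4c3)n2)cc1`: 4.68%

For the measured compounds named here, compound 2 and compound 1 are the only two numbers available, and they lie within the usual scatter of each other: the single measured step, a number 0.5 percentage points lower from compound 1 to compound 2 (within the scatter), moves nothing that can be told apart from repeat measurements. Compound 3, `c1csc(-c2cn3ccnc3c(-c3ccc4ncn(C5CCCCC5)c4c3)n2)c1`, has not yet been measured. Its difference from compound 2 is thiophen-2-yl in place of 4-acetylphenyl on an aromatic carbon. Going by the values given here, the one step already measured bears on this change only loosely: it altered the same place, swapping bromo for 4-acetylphenyl, and left the inhibition essentially unchanged. With both measured numbers sitting at the low end of the inhibition scale, and no group at this place having made a visible difference so far, the expected step of a number 0.3 percentage points higher from compound 2 to compound 3 (within the scatter) is none beyond the scatter. Compound 3 is therefore estimated at 5%, with a range from 0% to 15%.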

Compound 3, a percentage reported as inhibition, at one concentration (the size of the read-out at that concentration, not a potency): 12.2%
Compound 3: middle estimate off by 7.2 percentage points, on the low side, within the range that was stated.
By their numbers in this assay, from the lowest: compounds 2, 1 and 3 (each within the scatter of the next).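

In this assay, thiophen-2-yl now joins bromo and 4-acetylphenyl at this position, and neither a number 7.5 percentage points higher from compound 2 to compound 3 (within the scatter) nor a number 7 percentage points higher from compound 1 to compound 3 (within the scatter) lies beyond the usual scatter. Even a change from a six-membered carbon ring to a five-membered ring with a hetero atom therefore gives no difference that repeat measurements could separate, and the three groups cannot be ranked. Nothing available offers an explanation for these numbers.

As far as these compounds go, it remains open whether any group at this place can move the inhibition clearly beyond the scatter, for example an amine such as piperazine or a carboxylic acid. From the compounds shown here alone, it is also open whether changing the cyclohexyl group, elsewhere on the shared core, would matter more than anything tried at this position.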